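Hydroxy in Place of Nitro on a Second Core

The source may report more compounds than this note shows. Statements on the series, on what has been measured and on what is new or still open speak of the compounds shown alone.

Measured compounds:
compound 1, `COc1ccc(N(C)c2ccnc(Cl)n2)cc1[N+](=O)[O-]`: 4700 nM
compound 2, `COc1ccc(N(C)c2ccnc(Cl)n2)cc1O`: 422 nM
compound 3, `COc1ccc(N(C)c2cc(C)nc(C)n2)cc1[N+](=O)[O-]`: 4670 nM

All three compounds were tested in a functional assay on HCT-116 cells (Homo sapiens) for antiproliferative activity, read by MTT assay, with a stated time of 48 h; a lower number here means a stronger inhibitor, a higher number a weaker inhibitor. Compound 1 gives 4700 nM in this assay. Compound 2 gives 422 nM. Among the measured compounds shown here, the one change between them, (hydroxy in place of nitro on an aromatic carbon), brought an 11-fold lower number from compound 1 to compound 2 (1.05 log units; beyond the scatter).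

Compound 3 gives 4670 nM in this assay, a number that lies within the scatter of compound 1, so the two cannot be ranked against each other. The difference between the core of compound 1 and the core of compound 3 is not broken down here.

Compound 4, `COc1ccc(N(C)c2cc(C)nc(C)n2)cc1O`, has not yet been measured. It differs from compound 3 by hydroxy in place of nitro on an aromatic carbon. For the measured compounds named here, this is the same kind of change as the one from compound 1 to compound 2: in both the hydroxy sits ortho to a methoxy group, but in compound 4 it is meta to a large group, whereas in compound 2 it is meta to a group of 9 heavy atoms.

Going by the values given here, because the single earlier step of an 11-fold lower number from compound 1 to compound 2 (1.05 log units; beyond the scatter) was large and beyond the scatter, a step of similar size is expected here, with some caution since it rests on one pair only. The expected step is a 10-fold lower number from compound 3 to compound 4 (1.02 log units; beyond the scatter) in this assay. Compound 4 is therefore expected to give about 450 nM, with a likely range from 150 nM to 1500 nM.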

Compound 4, half-maximal inhibitory concentration: 126 nM
Beside the measured number, compound 4's estimate is 3.6-fold (0.55 log units) above it; the whole stated range lies above it.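

On the core of compound 3, putting hydroxy in place of nitro again lowered the number in this assay, giving a 37-fold lower number from compound 3 to compound 4 (1.57 log units; beyond the scatter), so the direction of the earlier step carried over from one core to the other. The size of the step did not carry over exactly, and the gap between the two is larger than repeated measurements alone would be expected to produce: the same change on two cores in this assay, an 11-fold lower number (1.05 log units; beyond the scatter) from compound 1 to compound 2 and a 37-fold lower number (1.57 log units; beyond the scatter) from compound 3 to compound 4, 3.3-fold (0.52 log units) apart, beyond the scatter of two such steps. Among the compounds shown here, this shows that the benefit of the change depends to some degree on the core that carries it, but with only two matched pairs it does not show which part of the core matters, nor does it give a rule for how large the step would be on any further core.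

The compounds shown hold only nitro or hydroxy on this aromatic carbon, so it remains open how an amine, a carboxylic acid or an ethoxy group would compare there. On these data alone, it also remains open whether the methoxy group is needed for the low numbers of the hydroxy compounds, which a longer chain or a plain hydrogen in its place could test.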